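Cyano in place of trifluoromethoxy: an expected small step

The source may hold more compounds than are shown below. What is called first, only, known or untested is meant among the compounds shown, and "the series" means these compounds.

Measured in an ADME assay on cells (Macrophage, Mus musculus) for cytotoxicity, read by resazurin assay, with a stated time of 3 days; a higher number here means a weaker inhibitor, a lower number a stronger inhibitor:
compound 1 `O=C(Nc1ccc(C(F)(F)F)cc1)c1cc(Cl)ccc1O` gives 2800 nM
compound 2 `O=C(Nc1ccc(OC(F)(F)F)cc1)c1cc(Cl)ccc1O` gives 7300 nM

Compound 2 holds the higher of the two numbers, with compound 1 as its nearest neighbour. Compound 3 `N#Cc1ccc(NC(=O)c2cc(Cl)ccc2O)cc1` carries cyano in place of trifluoromethoxy on an aromatic carbon. Among the measured compounds shown here, only one measured step bears on this change: a 2.6-fold higher number from compound 1 to compound 2 (0.42 log units; beyond the scatter), modest but beyond the scatter. It is a different exchange, so it suggests a likely size and gives no direction for cyano. A step no larger than that is expected in this assay, possibly none beyond the scatter. The estimate means a 1.1-fold higher number from compound 2 to compound 3 (0.04 log units; within the scatter). The expected value for compound 3 is 8000 nM, with an estimated range from 2800 nM to 23000 nM.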

Compound 3, half-maximal inhibitory concentration: 11000 nM
Estimate against measurement, compound 3: 1.4-fold (0.14 log units) below; low and high end bracket the measured number.
By their numbers in this assay, from the lowest: compound 1; then compounds 2 and 3 (each within the scatter of the next).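

In this assay, the exchange of trifluoromethoxy for cyano on this aromatic carbon gives a 1.5-fold higher number from compound 2 to compound 3 (0.18 log units; within the scatter) and so does not separate these two groups. Cyano in place of trifluoromethyl gives a 3.9-fold higher number from compound 1 to compound 3 (0.59 log units; beyond the scatter) and sets compound 1 apart from compound 3 as well as from compound 2. Nothing measured here accounts for these steps. Going by these compounds, whether an amine, a carboxylic acid or a longer chain at this position would read with compound 1 or with compound 2 and compound 3 remains open.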